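The compounds below may be only part of what the source reports. "The series", "measured", "known", "first", "only" and "open" are said of these compounds alone.

The measured compounds, each read in a functional assay on K562/Adr cells (Homo sapiens) for cytotoxicity, read by sulforhodamine B assay, with a stated time of 48 h; a higher number here means a weaker inhibitor, a lower number a stronger inhibitor:

compound 1 `CCN(CC)CCCn1c(=O)/c(=C/c2cc(OC)c(OC)c(OC)c2)s/c1=C1\C(=O)Nc2ccc(Cl)cc21` gives 1650 nM
compound 2 `CCN(CC)CCCn1c(=O)/c(=C/c2cc(OC)c(OC)c(OC)c2)s/c1=C1/C(=O)Nc2ccc(Cl)cc21` gives 1650 nM
compound 3 `CCN(CC)CCCn1c(=O)/c(=C/c2ccc(O)cc2)s/c1=C1\C(=O)Nc2ccc(Cl)cc21` gives 48800 nM

Compound 1 stands level with compound 2, and the two together hold the lowest numbers of the three; compound 3 is the furthest away. The step of no change at the digits printed from compound 1 to compound 2 (within the scatter) is explained by the fact that compounds 1 and 2 differ only in the configuration as drawn, so drawing the double bond the other way leaves the read-out where it was. The step of a 30-fold higher number from compound 1 to compound 3 (1.47 log units; beyond the scatter) shows that swapping the aryl group on the double-bonded chain carbon matters a great deal.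

Compound 4 `CCN(CC)CCCn1c(=O)/c(=C/c2cc(OC)c(OC)c(OC)c2)s/c1=C1\C(=O)Nc2ccc(C)cc21` is the next compound to follow from compound 1. The change is methyl in place of chloro on an aromatic carbon. Neither measured step touches this part of the shared core: one changed only configuration, the other the aryl group elsewhere. Nothing measured here therefore points to a shift, and a step within the scatter is expected, a 1.1-fold higher number from compound 1 to compound 4 (0.04 log units; within the scatter). Compound 4 is estimated to give 1800 nM in this assay, with a range from 700 nM to 5000 nM.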

Compound 4, half-maximal inhibitory concentration: 2020 nM
The estimate for compound 4 lay 1.1-fold (0.05 log units) below the measured number, and the stated range covers the measured number.
By their numbers in this assay, from the lowest: compounds 1, 2 and 4 (each within the scatter of the next); then compound 3.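

Methyl in place of chloro on this aromatic carbon gives a 1.2-fold higher number from compound 1 to compound 4 (0.09 log units; within the scatter) in this assay. Among the compounds shown here, this is the first reading at this position, since the earlier steps changed only a double-bond configuration and the aryl group elsewhere. It shows that here one heavy atom can replace another, with neither group carrying hydrogen-bond donors or acceptors, without the number moving beyond the scatter. The information given offers no explanation for why this swap leaves the number within the scatter.

The compounds shown leave open whether this holds beyond these two groups, for instance with an amine, a carboxylic acid or a longer chain on this aromatic carbon. They also leave open whether methyl and chloro stay within the scatter of each other when 4-hydroxyphenyl replaces 3,4,5-trimethoxyphenyl, as in compound 3.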